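The source may report more compounds than this note shows. Statements on the series, on what has been measured and on what is new or still open speak of the compounds shown alone.

In a functional assay (Homo sapiens) for inhibition of Nucleic Acid, tested at 100 uM (a lower number here means less inhibition, a higher number more inhibition at the concentration tested (going by the name of the read-out)), compound 1 `CSc1[nH]ccc2ncnc1-2` gives 4%. Compound 2 `CC1OC(n2cnc3c(N)nccc32)CC1O` gives 3% in this assay, and the two numbers lie within the scatter of one another, so neither can be set above the other. Compound 3 `OC[C@H]1O[C@@H](n2cnc3cnccc32)[C@H](O)[C@@H]1O` gives 13%; 1% (2 entries) in this assay; its repeated entries, (the several entries of compound 3 in this assay, 13%; 1% (2 entries)), show how far single readings of this kind can wander from each other. All three measured compounds therefore show only slight inhibition at the concentration tested.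

Compound 4 `Sc1[nH]ccc2ncnc1-2` has not yet been measured. It differs from compound 1 by hydrogen in place of methyl on a sulfur. Going by the values given here, no measured pair in this set shows what such a change does in this assay, so the expectation rests on the low readings of the measured compounds alone. The step of a number 1 percentage points higher from compound 1 to compound 4 (within the scatter) is expected to be none beyond the scatter, in either direction. Compound 4 is accordingly estimated at 5% in this assay, with a range from -5% to 18%.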

Compound 4, a percentage reported as inhibition, at one concentration (the size of the read-out at that concentration, not a potency): 26%
Compound 4: the middle estimate sits 21 percentage points below what was measured; the measured number lies above the stated range.
By their numbers in this assay, from the lowest: compounds 2 and 1 (each within the scatter of the next); then compound 4.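

On a sulfur whose other neighbours are aromatic carbon, the change from methylsulfanyl to sulfanyl gives a number 22 percentage points higher from compound 1 to compound 4 (beyond the scatter) in this assay. Going by these compounds alone, this is the first evidence in the set that this position matters: with the core of compound 1 unchanged, this single change is enough to produce a difference beyond the scatter. The size of that difference should still be read with care, as compound 1 and compound 4 have one entry each and repeated entries of another compound can lie far apart: the several entries of compound 3 in this assay, 13%; 1% (2 entries)

The compounds shown leave open how an ethyl group on this sulfur, or an amine in place of the sulfur, would read. They also leave open whether the step holds on any other core, as it rests on this one pair alone.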